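Dichlorophenyl sulfonyl hydrazide as successor to acetamidophenyl

The source may hold more compounds than are shown below. What is called first, only, known or untested is meant among the compounds shown, and "the series" means these compounds.

Measured so far in a functional assay on K562 cells (Homo sapiens) for antiproliferative activity; on this read-out lower numbers stand for stronger inhibition of growth and higher numbers for weaker inhibition of growth:
compound 1 `CC(=O)Nc1ccc(S(=O)(=O)NNC(=O)c2cccnc2Nc2ccc(Cl)cc2)cc1`, > 100000 nM
compound 2 `O=C(NNS(=O)(=O)c1ccc(F)cc1)c1cccnc1Nc1ccc(Cl)cc1Cl`, 83200 nM

Compound 1 stands only at a limit of this assay, not at a number; its result is the limit of > 100000 nM in this assay, at which 1 of the 2 values shown sits. Within the data shown here, compound 2 gives 83200 nM, a numbered reading, but the two structures differ in more than one place, so no step between them is drawn.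

Compound 3 `O=C(NNS(=O)(=O)c1ccc(Cl)cc1Cl)c1cccnc1Nc1ccc(Cl)cc1` is not yet measured. Relative to compound 1 it carries 2,4-dichlorophenyl in place of 4-acetamidophenyl on a sulfonyl sulfur; the rest of the shared core of compound 1 is kept.

Among the measured compounds shown here, no measured step covers this change. Because compound 1 sits at the limit (the limit of > 100000 nM in this assay, at which 1 of the 2 values shown sits), any numbered value for compound 3 would already mean a move toward stronger inhibition; the size of such a move is open, and a result at the limit again is also possible. The expectation for compound 3 is 60000 nM, within 20000 nM to 150000 nM, a step of an at least 1.6-fold lower number from compound 1 to compound 3 (0.22 log units; that floor lies within the scatter).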

Compound 3, concentration for total growth inhibition: 25700 nM
For compound 3 the middle estimate is 2.3-fold (0.37 log units) above the measured one; the measured number falls inside the stated range.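

In this assay, 2,4-dichlorophenyl in place of 4-acetamidophenyl on a sulfonyl sulfur, with the rest of the shared core of compound 1 kept, gives an at least 3.8-fold lower number from compound 1 to compound 3 (0.59 log units; beyond the scatter). Among these compounds, this is the first readable step, and it shows that the group at this place on the sulfonyl sulfur can bring the read-out to a numbered value, with the size of the step fixed only as a lower bound. Compound 1 stands at a limit, not at a number: the limit of > 100000 nM in this assay, at which 1 of the 3 values shown sits.

The compounds shown do not separate the departure of 4-acetamidophenyl from the arrival of 2,4-dichlorophenyl, as the whole group changes in one step. Going by these compounds, how a 4-aminophenyl group or a plain methyl on the sulfonyl sulfur would read in this assay also remains open.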